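The source may report more compounds than this note shows. Statements on the series, on what has been measured and on what is new or still open speak of the compounds shown alone.

Working notes on the series. For the measured compounds named here, the three compounds measured so far share one core; compound 1 `Cc1ccnc(OC(c2ccc(C(F)(F)F)cc2)C2CCN(C(C)CCNC(=O)c3c(Cl)cncc3Cl)CC2)c1` in an ADME assay on PBMC cells (Homo sapiens) for cytotoxicity (on this read-out higher numbers stand for lower toxicity in this test and lower numbers for higher toxicity in this test), gives 33600 nM. Compound 3 `CCO/N=C(/c1ccc(Br)cc1)C1CCN(C(C)CCNC(=O)c2c(Cl)cncc2Cl)CC1` in this assay gives 33800 nM, and these two numbers lie within the scatter of each other. Compound 2 `CC(CCNC(=O)c1c(Cl)cncc1Cl)N1CCC(C(Oc2cccc(C(F)(F)F)c2)c2ccc(C(F)(F)F)cc2)CC1` in this assay gives 7000 nM, so compound 1 stands together with compound 3 at the upper end of the three numbers, with compound 2 clearly lower.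

Going by the values given here, the only single-point step measured so far is a 4.8-fold lower number from compound 1 to compound 2 (0.68 log units; beyond the scatter), where the aryl on the oxygen on the saturated carbon was exchanged. Compound 4 `COC(=O)c1cccc(OC(c2ccc(C(F)(F)F)cc2)C2CCN(C(C)CCNC(=O)c3c(Cl)cncc3Cl)CC2)n1` is not yet measured; it differs from compound 1 in that (6-(methoxycarbonyl)pyridin-2-yl in place of 4-methylpyridin-2-yl on an oxygen on a saturated carbon). Among the compounds with values here, the ring on the oxygen stays a pyridine, unlike the step to compound 2, and the only comparable change of this kind was modest and downward. A step of at most that size, or none beyond the scatter, is expected in this assay. For compound 4 the estimate in this assay is 24000 nM, within 9000 nM to 50000 nM, which means an expected step of a 1.4-fold lower number from compound 1 to compound 4 (0.15 log units; within the scatter).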

Compound 4, half-maximal cytotoxic concentration: 14600 nM
For compound 4 the middle estimate is 1.6-fold (0.22 log units) above the measured one, and the stated range covers the measured number.
By their numbers in this assay, from the lowest: compound 2; then compound 4; then compounds 1 and 3 (each within the scatter of the next).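

On the oxygen on a saturated carbon, the ring can stay a pyridine and the number in this assay still moves beyond the scatter: 6-(methoxycarbonyl)pyridin-2-yl in place of 4-methylpyridin-2-yl gives a 2.3-fold lower number from compound 1 to compound 4 (0.36 log units; beyond the scatter), so among these compounds a lower number does not depend on exchanging the pyridine for a phenyl ring. The same position also separates the two lower-lying groups, with 6-(methoxycarbonyl)pyridin-2-yl in place of 3-(trifluoromethyl)phenyl giving a 2.1-fold higher number from compound 2 to compound 4 (0.32 log units; beyond the scatter), and with the step from compound 1 to compound 2 this puts all three groups at this position beyond the scatter of one another. Nothing available here accounts for this order of the three groups.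

The step from compound 1 to compound 4 removes the methyl group and brings in the methoxycarbonyl group at once, so the compounds shown do not separate the part played by each. Also open, as far as these compounds go, is how this position responds when the methoxycarbonyl group gives way to a carboxylic acid, a primary amide or a longer ester chain on the same pyridine ring, or when an amine stands there instead.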